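This account rests on a few compounds, and the source may have more. Where it says the series, first, only, none or still open, it means among the compounds named here.

Measured compounds and their permeability numbers:

compound 1, `COc1cc(C)c(S(=O)(=O)N(C)CCOCC(=O)N2CCN([C@@H]3CN4CCC3CC4)CC2)c(C)c1`: 1.4 10^-6 cm/s
compound 2, `COc1cc(C)c(S(=O)(=O)N(C)CCOCC(=O)N2CCC(N3CCN(C(C)C)CC3)CC2)c(C)c1`: 0.9 10^-6 cm/s
compound 3, `CCN1CCC(N2CCN(C(=O)COCCN(C)S(=O)(=O)c3c(C)cc(OC)cc3C)CC2)CC1`: 1.7 10^-6 cm/s

All three share the same sulfonamide-ether-amide core and differ only in the saturated amine part at the far end. In an ADME assay on Caco-2 cells (Homo sapiens) for permeability, tested at 50 uM (on this read-out lower numbers stand for lower permeability and higher numbers for higher permeability), compound 2 gives the smallest number of the three as read, but compound 1 and compound 3 both sit within the usual scatter of it, so the three are best regarded as indistinguishable on this read-out.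

Compound 4, `COc1cc(C)c(S(=O)(=O)N(C)CCOCC(=O)N2CCC(C3CCN(C)CC3)CC2)c(C)c1`, differs from compound 2 by 1-methylpiperidin-4-yl in place of 4-isopropylpiperazin-1-yl on a saturated ring carbon. One measured step offers a comparison: a 1.2-fold higher number from compound 1 to compound 3 (0.08 log units; within the scatter). That step also exchanges one saturated amine-bearing group for another of similar size, although it sits on an amine nitrogen rather than on a saturated ring carbon, and it stayed within the scatter. With no other guide, a small step is expected for compound 4, a 1.4-fold higher number from compound 2 to compound 4 (0.16 log units; within the scatter), with no clear direction beyond the scatter. Compound 4 is therefore estimated at 1.3 10^-6 cm/s, with a likely range from 0.6 10^-6 cm/s to 3 10^-6 cm/s in this assay.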

Compound 4, apparent permeability: 2.6 10^-6 cm/s
For compound 4 the middle estimate is 2.0-fold (0.30 log units) below the measured one; the range from low to high includes it.
By their numbers in this assay, from the lowest: compounds 2, 1, 3 and 4 (each within the scatter of the next, the first and the last beyond it).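

At this saturated ring carbon, the choice of group can shift the number in this assay: 1-methylpiperidin-4-yl in place of 4-isopropylpiperazin-1-yl gives a 2.9-fold higher number from compound 2 to compound 4 (0.46 log units; beyond the scatter), a modest step but the first in this set to clear the usual scatter, whereas the earlier exchange of one amine-bearing group for another, a 1.2-fold higher number from compound 1 to compound 3 (0.08 log units; within the scatter), did not. The change is also not a single edit, since the entering group has one nitrogen where the leaving group has two, carries a methyl where the other carries an isopropyl, and has fewer heavy atoms, and this one step cannot separate those differences. Nothing measured here indicates what lies behind the higher number.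

Two groups on the same ring carbon would pull these differences apart: 4-methylpiperazin-1-yl keeps both nitrogens with the methyl, while 1-isopropylpiperidin-4-yl keeps the isopropyl with one nitrogen. Also open, going by these compounds, is how a cyclohexyl group, which has no ring nitrogen, would read at this position.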